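The compounds below may be only part of what the source reports. "The series", "measured", "known", "first", "only" and "open" are said of these compounds alone.

Measured so far in a functional assay on SF-295 cells (Homo sapiens) for inhibition, read by sulforhodamine B assay, with a stated time of 48 h; a higher number here means a weaker inhibitor of growth, a lower number a stronger inhibitor of growth:

compound 1 `COc1ccc(NC(=O)Nc2n[nH]c3ccccc23)cc1` gives > 100000 nM
compound 2 `CCCCOc1ccc(NC(=O)n2nc(N)c3ccccc32)cc1` gives 21700 nM
compound 3 `Nc1nn(C(=O)Nc2c(F)cccc2F)c2ccccc12` gives 54800 nM

The value for compound 1 is a limit of this assay, not a number; (the limit of > 100000 nM in this assay, at which 1 of the 3 values shown sits). Among the two numbers obtained, compound 2 stands lowest, with compound 3 nearest at a number beyond the scatter above it.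

Compound 4 `Nc1nn(C(=O)Nc2ccc(Cc3ccccc3)cc2)c2ccccc12` is not yet measured. Against compound 2 the change is benzyl in place of butoxy on an aromatic carbon; the shared core and the urea linking it to the second ring are kept. Within the data shown here, no measured pair in this set differs in a single place, so there is no measured step to lean on for a change of this kind.

The butoxy and benzyl groups are of similar size, so the step from compound 2 to compound 4 in this assay is expected to be small, within the scatter, with no direction preferred: a 1.1-fold lower number from compound 2 to compound 4 (0.04 log units; within the scatter). Compound 4 is therefore estimated at 20000 nM, within a range of 5000 nM to 80000 nM.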

Compound 4, concentration for 50% growth inhibition: 530 nM
Estimate against measurement, compound 4: 38-fold (1.58 log units) above; the whole stated range lies above it.
By their numbers in this assay, from the lowest: compound 4; then compound 2; then compound 3. At a limit, above all of these: compound 1.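

In this assay, this first measured step shows that the aromatic carbon para to a large group is far from indifferent to its substituent: benzyl in place of butoxy gives a 41-fold lower number from compound 2 to compound 4 (1.61 log units; beyond the scatter), although the opening comparison treated the two groups as similar in size. The entering group brings a six-membered aromatic ring of carbon only and the leaving group brings an oxygen, so this single step cannot separate gaining the ring from losing the hydrogen-bond acceptor. Nothing measured here bears on why the step is so large.

On these data alone, it remains open whether the aromatic ring alone is enough or whether the carbon linking it also matters. A phenyl group, a phenoxy group or a cyclohexylmethyl group at this position would separate these readings.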